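The source may hold more compounds than are shown below. What is called first, only, known or untested is meant among the compounds shown, and "the series" means these compounds.

Measured so far:
- compound 1 `N#CC(/C=C/[C@@H](O)C[C@@H](O)CC(=O)O)=C(c1ccc(F)cc1)c1ccc(F)cc1`: 8000 nM
- compound 2 `CC(C)n1nnnc1C(C=C=C[C@@H](O)C[C@@H](O)CC(=O)O)=C(c1ccc(F)cc1)c1ccc(F)cc1`: 130000 nM
- compound 3 `COc1ccc(C(=C(/C=C/[C@@H](O)C[C@@H](O)CC(=O)O)c2nnnn2C)c2ccc(OC)cc2)cc1`: 1400 nM

In an assay for inhibition of 3-hydroxy-3-methylglutaryl-coenzyme A reductase (Rattus norvegicus) (a higher number here means a weaker inhibitor, a lower number a stronger inhibitor), compound 1 gives 8000 nM, the second highest of the three numbers. Compound 3 stands nearest to it, with a lower number that lies beyond the scatter; compound 2 stands furthest, with a much higher number, again beyond the scatter. Compound 2 and compound 3 each differ from compound 1 in more than one place, so no single change can be read from them.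

The next compound, compound 4 `CC(C)C(/C=C/[C@@H](O)C[C@@H](O)CC(=O)O)=C(c1ccc(F)cc1)c1ccc(F)cc1`, differs from compound 1 in one place only: isopropyl in place of cyano on a double-bonded chain carbon bound to two double-bonded chain carbons. Going by the values given here, no measured pair shows this change on its own, so the size of the step is open. The cyano group is the only hydrogen-bond acceptor that leaves, and the rest of the core, the diene chain and the dihydroxy acid are kept. The expectation is a step toward a lower number in this assay, of a size comparable to the gap that separates compound 1 from compound 3, though the uncertainty is wide in both directions.

For compound 4 the estimate in this assay is 1500 nM, within 300 nM to 8000 nM, which means an expected step of a 5.3-fold lower number from compound 1 to compound 4 (0.73 log units; beyond the scatter).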

Compound 4, half-maximal inhibitory concentration: 230 nM
The estimate for compound 4 lay 6.5-fold (0.81 log units) above the measured number; the whole stated range lies above it.
By their numbers in this assay, from the lowest: compound 4; then compound 3; then compound 1; then compound 2.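

In this assay, going by these compounds alone, isopropyl in place of cyano on a double-bonded chain carbon bound to two double-bonded chain carbons gives a 35-fold lower number from compound 1 to compound 4 (1.54 log units; beyond the scatter), a large step and the first single-place change that can be read. This position therefore does not require the cyano group or its hydrogen-bond acceptor, and an all-carbon group there is compatible with much stronger inhibition in the compounds compared. No measurement on hand explains the size of the step.

Still open, going by these compounds, is how the number responds to other groups at this carbon, such as ethyl, tert-butyl, cyclopropyl or a primary amide. Also open, on these data alone, is whether the same change carries over to the other compounds, which differ from compound 1 in more than one place.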